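A few compounds are considered here, and "the series" means these few. Any claim that something is new, unique, unknown or untested is made for them only; others in the source may bear on it.

Measured in a functional assay on A549 cells (Homo sapiens) for cytotoxicity, read by MTT assay, with a stated time of 72 h; on this read-out higher numbers stand for weaker inhibition and lower numbers for stronger inhibition:

Compound 1, `COc1ccc(OC)c(/C=N/NC(=O)Nc2ccc(Oc3ccnc(-c4nncn4CCN(C)C)c3)c(F)c2)c1`: 1950 nM
Compound 2, `CN(C)CCn1cnnc1-c1cc(Oc2ccc(NC(=O)N/N=C/c3ccc(F)cc3F)cc2F)ccn1`: 1870 nM
Compound 3, `CN(C)CCn1cnnc1-c1cc(Oc2ccc(NC(=O)N/N=C/c3cc(Br)c(O)c(Br)c3)cc2F)ccn1`: > 100000 nM (a limit of the assay, not a number)

Among the compounds with values here, compound 2 and compound 1 sit within the scatter of each other, as the step of a 1.0-fold lower number from compound 1 to compound 2 (0.02 log units; within the scatter) shows; the only other measured compound, compound 3, gave a limit rather than a number. The step to be followed leads from compound 2 to compound 4, `CN(C)CCn1cnnc1-c1cc(Oc2ccc(NC(=O)N/N=C/c3ccc(O)c(F)c3)cc2F)ccn1`, with the change (3-fluoro-4-hydroxyphenyl in place of 2,4-difluorophenyl on a carbon with a double bond to nitrogen).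

Within the data shown here, two measured steps bear on it, both ending in a phenyl ring that carries a hydroxyl: an at least 51-fold higher number from compound 1 to compound 3 (1.70 log units; beyond the scatter) and an at least 53-fold higher number from compound 2 to compound 3 (1.72 log units; beyond the scatter). Both are large and both run toward weaker inhibition, as the limit of > 100000 nM in this assay, at which 1 of the 3 values shown sits, records. The change to compound 4 also brings in a hydroxyl, though with a single fluorine in place of two bromines, so the comparison is only partial. A step toward weaker inhibition beyond the scatter is therefore expected in this assay, though smaller than the steps to compound 3, giving an estimated 6.4-fold higher number from compound 2 to compound 4 (0.81 log units; beyond the scatter). Compound 4 is thus expected to give about 12000 nM, with a range from 3000 nM to 60000 nM.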

Compound 4, half-maximal inhibitory concentration: 13400 nM
Compound 4: the middle estimate sits 1.1-fold (0.05 log units) below what was measured, and the stated range covers the measured number.
By their numbers in this assay, from the lowest: compounds 2 and 1 (each within the scatter of the next); then compound 4. At a limit, above all of these: compound 3.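

In this assay, a hydroxyl-bearing ring with a single fluorine and no bromine still gives weaker inhibition than either ring without a hydroxyl on the carbon with a double bond to nitrogen, with a 7.2-fold higher number from compound 2 to compound 4 (0.86 log units; beyond the scatter) and a 6.9-fold higher number from compound 1 to compound 4 (0.84 log units; beyond the scatter). Compound 3 remains a limit of the assay, not a number: the limit of > 100000 nM in this assay, at which 1 of the 4 values shown sits. Against that limit, 3-fluoro-4-hydroxyphenyl in place of 3,5-dibromo-4-hydroxyphenyl gives an at least 7.4-fold lower number from compound 3 to compound 4 (0.87 log units; beyond the scatter), so the two hydroxyl-bearing rings at this place are not equivalent, and compound 4 gives the first measured number for such a ring.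

On these data alone, whether the rise from compound 2 traces to the hydroxyl itself or to the altered fluorines stays open, as the 2,4-difluorophenyl and 3-fluoro-4-hydroxyphenyl rings differ in both at once. As far as these compounds go, it is also open how an amino group or a carboxylic acid in the hydroxyl's place would read in this assay.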